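A few compounds are considered here, and "the series" means these few. Any claim that something is new, unique, unknown or untested is made for them only; others in the source may bear on it.

Measured compounds in an assay on isolated protein for inhibition of Polyunsaturated fatty acid 5-lipoxygenase (Homo sapiens); a lower number here means a stronger inhibitor, a higher number a weaker inhibitor:
Compound 1 `OCCOc1ccc(C2(c3ccc(OCCO)cc3)CC3CCC2C3)cc1`: compound 1 gives > 8000 nM, which is a limit of the assay.
Compound 2 `O=C(O)COc1ccc(C2(c3ccc(OCc4ccc5ccccc5n4)cc3)CC3CCC2C3)cc1`: compound 2 gives > 6300 nM, which is a limit of the assay.
Compound 3 `Oc1ccc(OCc2ccc3ccccc3n2)cc1C1(c2ccccc2)CC2CCC1C2`: compound 3 gives 5000 nM.

Among these three, compound 3 is the only one with an actual number in this assay; the other two results are limits, one of them the limit of > 8000 nM in this assay, at which 1 of the 3 values shown sits, and the other (the limit of > 6300 nM in this assay, at which 1 of the 3 values shown sits), so no step between measured compounds can be computed. Compound 4 `COC(=O)COc1ccc(OCc2ccc3ccccc3n2)cc1C1(c2ccccc2)CC2CCC1C2` has not yet been measured in this assay. It differs from compound 3 in one place: (methoxycarbonyl)methyl in place of hydrogen on an oxygen on an aromatic ring. Going by the values given here, with no measured step to lean on, the expected effect is small: the step from compound 3 to compound 4 is estimated as a 1.3-fold higher number from compound 3 to compound 4 (0.11 log units; within the scatter), a change that may not exceed the usual scatter, with a slight lean toward weaker inhibition. On that basis compound 4 is expected to give about 6500 nM in this assay, most likely between 2000 nM and 20000 nM, with a real chance that only a limit is reported.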

Compound 4, half-maximal inhibitory concentration: > 6000 nM
Compound 4: only a limit was reported; the forecaster's own chance of this, stated with the estimate: 45%; the middle value is on the limit's open side.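

Going by these compounds alone, at this oxygen on the aromatic ring, the change from hydroxy to (methoxycarbonyl)methoxy gives the first step that can be read in this set: an at least 1.2-fold higher number from compound 3 to compound 4 (0.07 log units; that floor lies within the scatter). In this assay compound 4 reaches only a limit of the assay: the limit of > 6000 nM in this assay, at which 1 of the 4 values shown sits. The step therefore has a floor but no size, so the change may do nothing beyond the scatter or may weaken inhibition by much more, and the only thing it rules out is a measured gain in strength from this ester-bearing group.

What the compounds shown leave open is how this oxygen responds to other groups, such as a plain methoxy or an aminoethoxy chain. They also leave open whether any group here can bring the number clearly below that of compound 3, at 5000 nM.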